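The compounds below may be only part of what the source reports. "The series", "measured", "known", "first", "only" and "open" are said of these compounds alone.

Of the compounds shown here, three built on one shared core have been tested in a functional assay on DU-145 cells (Homo sapiens) for cytotoxicity, read by sulforhodamine B assay, with a stated time of 2 days, tested at 100 uM; on this read-out lower numbers stand for less inhibition and higher numbers for more inhibition at the one concentration tested (going by the name of the read-out). Compound 1 `COc1cccc(Cc2nc3c(-c4ccc(Cl)cc4)n[nH]c3c(=O)n2NC(=O)c2ccccc2)c1` gives 93.2% in this assay. Compound 2 `O=C(Nn1c(CCc2ccccc2)nc2c(-c3ccc(Cl)cc3)n[nH]c2c1=O)c1ccccc1` gives 85.6%. Compound 3 `CCCCc1nc2c(-c3ccc(Cl)cc3)n[nH]c2c(=O)n1NC(=O)c1ccccc1` gives 93.1%. Among these three numbers compound 3 stands second highest; the step of a number 0.1 percentage points lower from compound 1 to compound 3 (within the scatter) shows its nearest neighbour, and the step of a number 7.5 percentage points higher from compound 2 to compound 3 (within the scatter) shows its furthest. The third measured step, a number 7.6 percentage points lower from compound 1 to compound 2 (within the scatter), likewise stays within the scatter, so the three compounds cannot be ranked by this assay.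

Compound 4 `O=C(Nn1c(CCC2CCCC2)nc2c(-c3ccc(Cl)cc3)n[nH]c2c1=O)c1ccccc1` is the next compound to be measured. It differs from compound 3 by cyclopentyl in place of ethyl on a saturated chain carbon, two bonds along the chain from an aromatic carbon. Among the compounds with values here, the one measured step at this same place, a number 7.5 percentage points higher from compound 2 to compound 3 (within the scatter), was within the scatter, and the two steps at the neighbouring chain carbon were also within the scatter. Changes at this side chain have therefore so far left this assay essentially unmoved, and the step of a number 2.1 percentage points lower from compound 3 to compound 4 (within the scatter) is expected to be no larger than the scatter. For compound 4 the estimate in this assay is 91%, within a range from 80% to 98%.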

Compound 4, a percentage reported as inhibition, at one concentration (the size of the read-out at that concentration, not a potency): 89.6%
For compound 4 the middle estimate is 1.4 percentage points above the measured one, and the stated range covers the measured number.
By their numbers in this assay, from the lowest: compounds 2, 4, 3 and 1 (each within the scatter of the next).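

Adding a non-aromatic ring of carbon, cyclopentyl, at the end of the side chain is new here, and in this assay it stays within the scatter of all three earlier compounds: a number 3.5 percentage points lower from compound 3 to compound 4 (within the scatter), a number 4 percentage points higher from compound 2 to compound 4 (within the scatter) and a number 3.6 percentage points lower from compound 1 to compound 4 (within the scatter). Ethyl, phenyl and cyclopentyl at this place therefore cannot be told apart by this read-out, and the same holds for the cyclopentylmethyl and 3-methoxyphenyl groups when the difference is read one bond closer to the core. No measurement is available that explains why these changes in the side chain leave the number so little moved.

From the compounds shown here alone, whether an amine or a carboxylic acid at the end of this chain would shift the number remains open. Also open is whether these four compounds would separate at lower concentrations, as each is shown at a single concentration.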